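The compounds below may be only part of what the source reports. "The series", "measured", "known", "first", "only" and "open" are said of these compounds alone.

Measured compounds and their values in an ADME assay on HepG2 2.2.15 cells (Homo sapiens) for cytotoxicity; a higher number here means that more compound is tolerated, a lower number that less compound is tolerated:

Compound 1, `O=C(Nc1ncc(Cc2ccc(F)cc2)s1)c1ccccc1`: in this assay compound 1 gives "not toxic" (no number reported).
Compound 2, `Cc1cc(Br)cc(OC(c2ccc(Cl)cc2)c2cnc(NC(=O)OC(C)(C)C)s2)c1`: in this assay compound 2 gives > 50000 nM, which is a limit of the assay and not a number.
Compound 3, `Clc1ccc(C(Oc2ccc3cc(Br)ccc3c2)c2cnc(NCC3CCCCC3)s2)cc1`: in this assay compound 3 gives "not toxic" (no number reported).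

Compound 3 therefore has no single number to stand on. Of the other two entries, one is likewise only a word, and the other sits at the limit of > 50000 nM in this assay, at which 1 of the 3 values shown sits. Nothing among the three values points to harm to the cells at the concentrations tested, and no two of them can be set against each other as a measured step.

Compound 4, `CCN(CC)C(=O)Nc1ncc(C(Oc2ccc3cc(Br)ccc3c2)c2ccc(Cl)cc2)s1`, has not yet been measured. It keeps the whole of compound 3 except for one exchange: diethylcarbamoyl in place of cyclohexylmethyl on a nitrogen on an aromatic ring. For the measured compounds named here, since no step between measured compounds exists here, the size of the step to compound 4 in this assay can only be guessed; the expectation is no step beyond the usual scatter, in either direction, with compound 4 staying tolerated as the three measured compounds are.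

Compound 4 is expected to give about 50000 nM in this assay, most likely reported as a limit, with the estimate ranging from 20000 nM to 100000 nM.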

Compound 4, half-maximal cytotoxic concentration: "not toxic" (no number reported)
Compound 4: no number reported, and the estimate cannot be compared.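

In this assay compound 3 gives "not toxic" (no number reported) and compound 4 gives "not toxic" (no number reported), so no step can be read between them. The compounds shown leave open at what concentration, if any, they harm the cells, and whether going from cyclohexylmethyl to diethylcarbamoyl shifts that concentration.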